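This account rests on a few compounds, and the source may have more. Where it says the series, first, only, none or still open, it means among the compounds named here.

Compound 2 `CCCCNC(=O)Nc1cc(N2CCCCC2)nc(N)[n+]1[O-]` and compound 1 `N#CCCNC(=O)Nc1cc(N2CCCCC2)nc(N)[n+]1[O-]` share one core and differ only in the chain on the urea. In a functional assay on HL-60 cells (Homo sapiens) for activation, read by MTT assay (a higher number here means a weaker inhibitor, a lower number a stronger inhibitor), compound 2 gives only a limit, > 10000 nM. Compound 1 likewise gives only a limit in this assay, > 10000 nM. The step that the two limits leave unreadable from compound 1 to compound 2 cannot be read, since both values sit at the limit of > 10000 nM in this assay, at which 2 of the 2 values shown sit. Compound 3 `Nc1nc(N2CCCCC2)cc(NC(=O)NCc2ccccc2)[n+]1[O-]` differs from compound 2 by phenyl in place of propyl on a saturated chain carbon bound to an amide-type nitrogen. Among the measured compounds shown here, no measured step bears on this change. Compound 3 is therefore expected near 12000 nM, between 3000 nM and 50000 nM. The expected step that the limit leaves unreadable from compound 2 to compound 3 is none beyond the scatter.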

Compound 3, half-maximal inhibitory concentration: > 10000 nM
Compound 3 was reported as a limit (the forecaster's own chance of this, stated with the estimate: 70%); the middle value does not contradict the limit.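

No new step can be read from compound 2 and compound 3, as each value is only a limit: the limit of > 10000 nM in this assay, at which 3 of the 3 values shown sit.

The compounds shown leave open whether any chain on the urea of the shared core gives a readable value.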